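Pyrazinyl Amide in a Diamide Series at the Glutamate Receptor

The compounds below may be only part of what the source reports. "The series", "measured", "known", "first", "only" and "open" are said of these compounds alone.

Two diamides have been measured in a functional assay on HEK293 cells for antagonist activity at metabotropic glutamate receptor 5 (Homo sapiens), read by FLIPR and calcium flux; on this read-out higher numbers stand for weaker inhibition and lower numbers for stronger inhibition. Compound 1 `N#Cc1cccc(C(=O)NC2CCCC(NC(=O)c3ccccn3)C2)c1` gives 531 nM in this assay. Compound 2 `COc1ccc(C(=O)N[C@H]2CCC[C@H](NC(=O)c3cccc(Cl)c3)C2)cc1` gives 266 nM in this assay, which is the lower of the two numbers, though the gap to compound 1 stays within the usual scatter, so the two compounds cannot be told apart on these data. The next compound, compound 3 `O=C(N[C@H]1CCC[C@H](NC(=O)c2cnccn2)C1)c1cccc(Cl)c1`, is not yet measured; it carries pyrazin-2-yl in place of 4-methoxyphenyl on a carbonyl carbon. Compound 1 already shows that a nitrogen-containing six-membered ring on one amide is tolerated, so compound 3 is expected to stay close to compound 2, with at most a small step in this assay toward weaker inhibition. The expectation is a step of a 1.9-fold higher number from compound 2 to compound 3 (0.27 log units; within the scatter). Compound 3 is estimated at 500 nM, within a range of 150 nM to 1700 nM.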

Compound 3, half-maximal inhibitory concentration: 1370 nM
Compound 3: the middle estimate sits 2.7-fold (0.44 log units) below what was measured; low and high end bracket the measured number.
By their numbers in this assay, from the lowest: compounds 2 and 1 (each within the scatter of the next); then compound 3.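

In this assay, for the compounds shown here, putting pyrazin-2-yl in place of 4-methoxyphenyl on a carbonyl carbon gives a 5.2-fold higher number from compound 2 to compound 3 (0.71 log units; beyond the scatter), the first step that lies beyond the scatter. This position is therefore not indifferent to the group it carries: here, a six-membered aromatic ring with 2 hetero atoms gives weaker inhibition than the carbon-only ring with its methoxy group. Nothing available bears on why this step occurs.

This one step changes the ring and removes the methoxy group together, so it does not show how much each change contributes. Going by these compounds, whether an unsubstituted phenyl or a pyridin-2-yl on this carbonyl carbon would stand nearer to compound 2 or to compound 3 remains open.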